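Moving a hydroxyl around the hydrazone aryl ring

The source may hold more compounds than are shown below. What is called first, only, known or untested is meant among the compounds shown, and "the series" means these compounds.

Measured compounds in a functional assay on MKN-45 cells (Homo sapiens) for cytotoxicity, read by MTT assay, with a stated time of 72 h; a lower number here means a stronger inhibitor, a higher number a weaker inhibitor:
compound 1 `CN(C)CCn1cnnc1-c1cc(Oc2ccc(NC(=O)N/N=C/c3cccc(O)c3)cc2F)ccn1`, 1370 nM
compound 2 `CN(C)CCn1cnnc1-c1cc(Oc2ccc(NC(=O)N/N=C/c3ccc(F)cc3Cl)cc2F)ccn1`, 870 nM
compound 3 `CN(C)CCn1cnnc1-c1cc(Oc2ccc(NC(=O)N/N=C/c3cccc(Cl)c3Cl)cc2F)ccn1`, 51 nM

Compound 1 gives the highest number of the three. Its gap to compound 2 is a 1.6-fold lower number from compound 1 to compound 2 (0.20 log units; within the scatter), whereas compound 3 is far stronger, a 27-fold lower number from compound 1 to compound 3 (1.43 log units; beyond the scatter).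

Compound 4 `CN(C)CCn1cnnc1-c1cc(Oc2ccc(NC(=O)N/N=C/c3ccc(O)cc3)cc2F)ccn1` differs from compound 1 only on the hydrazone carbon: 4-hydroxyphenyl in place of 3-hydroxyphenyl on a carbon with a double bond to nitrogen. For the measured compounds named here, no measured step moves a hydroxyl from one ring position to another; the steps that exist swap the hydroxyphenyl for halogenated rings, and only the 2,3-dichlorophenyl change is large. A shift of the same hydroxyl is therefore expected to leave this assay roughly where compound 1 sits, with the step of a 1.1-fold higher number from compound 1 to compound 4 (0.04 log units; within the scatter) expected to stay within the scatter. The estimate for compound 4 is 1500 nM, ranging from 500 nM to 4500 nM.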

Compound 4, half-maximal inhibitory concentration: 820 nM
Estimate against measurement, compound 4: 1.8-fold (0.26 log units) above; measured number inside the range.
By their numbers in this assay, from the lowest: compound 3; then compounds 4, 2 and 1 (each within the scatter of the next).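

Moving the hydroxyl from 3-hydroxyphenyl to 4-hydroxyphenyl, on a carbon with a double bond to nitrogen, directly tests its ring position, and in this cell assay, this assay, the shift stays within the scatter (a 1.7-fold lower number from compound 1 to compound 4 (0.22 log units; within the scatter)). Replacing the 2-chloro-4-fluorophenyl ring with 4-hydroxyphenyl also stays within the scatter (a 1.1-fold lower number from compound 2 to compound 4 (0.03 log units; within the scatter)), while replacing 2,3-dichlorophenyl gives a large loss (a 16-fold higher number from compound 3 to compound 4 (1.21 log units; beyond the scatter)). No available evidence accounts for these differences. On these data alone, whether an aminophenyl or a methoxyphenyl ring at this place would match the hydroxyphenyl compounds or approach compound 3 remains open.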